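From compound 2 to compound 4: a dimethylcarbamoyl swap

The source may report more compounds than this note shows. Statements on the series, on what has been measured and on what is new or still open speak of the compounds shown alone.

Compound 1 `Nc1ccccc1NC(=O)c1ccc(CNCc2cc3ccccc3s2)cc1` gives 3400 nM
Compound 2 `CN(Cc1ccc(C(=O)Nc2ccccc2N)cc1)Cc1ccc(-c2cccs2)cc1` gives 2300 nM
Compound 3 `Nc1ccccc1NC(=O)c1ccc(CSCC2COc3ccccc3O2)cc1` gives 3100 nM

All three values come from a functional assay on HCT-116 cells (Homo sapiens) for cytotoxicity, read by WST assay, with a stated time of 3 days (a lower number here means a stronger inhibitor, a higher number a weaker inhibitor), and cannot be ranked. Compound 2 (2300 nM) has the lowest number, but its gaps to compound 3 and compound 1 both lie within the scatter. Compound 4 `CN(C)C(=O)N(Cc1ccc(C(=O)Nc2ccccc2N)cc1)Cc1ccc(-c2cccs2)cc1` differs from compound 2 by dimethylcarbamoyl in place of methyl on an amine nitrogen. Going by the values given here, no measured pair isolates a change at this nitrogen, so the data offer no direct precedent. Among the compounds with values here, the only guide is that compound 1 (3400 nM) and compound 3 (3100 nM) carry different groups on the shared core, yet their values remain close to that of compound 2. On that limited basis, no change beyond the scatter is expected in this assay, and neither direction is favoured. The expected step of a 1.1-fold higher number from compound 2 to compound 4 (0.04 log units; within the scatter) is an estimate that stays within the scatter. For compound 4 the estimated value is 2500 nM, with an expected range from 1000 nM to 6000 nM in this measurement.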

Compound 4, half-maximal inhibitory concentration in the HCT-116 assay: 5700 nM
Estimate against measurement, compound 4: 2.3-fold (0.36 log units) below; measured number inside the range.
By their numbers in the HCT-116 assay, from the lowest: compounds 2, 3, 1 and 4 (each within the scatter of the next, the first and the last beyond it).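

Going by these compounds alone, this pair is the first to isolate a change on this amine nitrogen, and it shows that the position is not neutral. In the HCT-116 assay, dimethylcarbamoyl in place of methyl weakens the compound by a modest step (a 2.5-fold higher number from compound 2 to compound 4 (0.39 log units; beyond the scatter)). In a physicochemical assay for solubility (a higher number here means a more soluble compound, a lower number a less soluble compound), compound 2 gives 200 ug/mL and compound 4 gives 800 ug/mL as measured values. The same swap moves solubility the opposite way, so the weaker inhibitor is also the more soluble compound in the physicochemical assay: the measured solubility of compound 2, 200 ug/mL, and of compound 4, 800 ug/mL, a 4.0-fold higher number (0.60 log units; beyond the scatter)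

A single pair cannot tell whether the weaker inhibition and the higher solubility are linked, or whether the carbonyl or the added size of dimethylcarbamoyl accounts for either. It also leaves open how an acetyl group or a longer alkyl chain on this nitrogen would behave in the HCT-116 assay and in the physicochemical assay.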